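The source may hold more compounds than are shown below. What is called first, only, known or untested is meant among the compounds shown, and "the series" means these compounds.

Measured compounds:
Compound 1, `COc1ccc(C(C)C)cc1CN[C@H]1[C@H](C(C)(C)C)[C@@H](C(=O)O)N(C(=O)C2CCCCC2)[C@H]1c1ccccc1`: 191%
Compound 2, `COc1ncc(C(C)(C)C)cc1CN[C@H]1[C@H](C(C)(C)C)[C@@H](C(=O)O)N(C(=O)C2CCCCC2)[C@H]1c1ccccc1`: 114%

In an assay on HBE cells for positive allosteric modulation of Cystic fibrosis transmembrane conductance regulator variant F508del (Homo sapiens) (on this read-out lower numbers stand for smaller maximal responses and higher numbers for larger maximal responses), compound 2 gives 114%, the lowest of the two values, while compound 1 gives 191%. For the measured compounds named here, the one measured step, a number 77 percentage points lower from compound 1 to compound 2 (beyond the scatter), came from exchanging the aromatic ring, not from changing a group on it. Compound 3, `COc1ncc(C(F)(F)F)cc1CN[C@H]1[C@H](C(C)(C)C)[C@@H](C(=O)O)N(C(=O)C2CCCCC2)[C@H]1c1ccccc1`, differs from compound 2 by trifluoromethyl in place of tert-butyl on an aromatic carbon. Going by the values given here, no measured step tests this exchange, so the change is expected to stay within the scatter, with a wide range: the estimated step is a number 4 percentage points lower from compound 2 to compound 3 (within the scatter). For compound 3 the expected value is 110%, between 75% and 150%.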

Compound 3, largest response reached (reported as percent of maximum), in percent of the reference or control that the assay uses: 85%
Compound 3: middle estimate off by 25 percentage points, on the high side; measured number inside the range.
By their numbers in this assay, from the lowest: compound 3; then compound 2; then compound 1.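

In this assay, the group on this aromatic carbon clearly counts: trifluoromethyl in place of tert-butyl gives a number 29 percentage points lower from compound 2 to compound 3 (beyond the scatter), although both groups hold the same number of heavy atoms. Taken together with the ring exchange, replacing 5-isopropyl-2-methoxyphenyl by 2-methoxy-5-(trifluoromethyl)pyridin-3-yl gives a number 106 percentage points lower from compound 1 to compound 3 (beyond the scatter). Nothing available explains why the response drops with this exchange. Still open, going by these compounds, is how a nitrile or a chlorine atom on this same carbon would compare with tert-butyl and trifluoromethyl.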